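A few compounds are considered here, and "the series" means these few. Any claim that something is new, unique, unknown or untested is made for them only; others in the source may bear on it.

Among the measured compounds shown here, compound 3 `COc1cc(Cl)cc(-c2nn(-c3cccc(NC(=O)Nc4ccc(Cl)c(C(F)(F)F)c4)c3)cc2-c2ccncc2)c1` stands second highest of the three numbers so far in a functional assay on RXF 393 cells (Homo sapiens) for inhibition, read by sulforhodamine B assay, with a stated time of 48 h, tested at 10 uM (on this read-out higher numbers stand for a weaker effect at the one concentration tested and lower numbers for a stronger effect), where compound 3 gives -30%. Its nearest neighbour is compound 2 `O=C(Nc1cccc(-n2cc(-c3ccncc3)c(-c3cc(O)cc(Cl)c3)n2)c1)Nc1ccc(Cl)c(Cl)c1`, which in this assay gives -70.3%; furthest away lies compound 1 `COc1cc(Cl)cc(-c2nn(-c3cccc(NC(=O)c4ccc(Cl)c(Cl)c4)c3)cc2-c2ccncc2)c1`, which gives 59.2%. Compound 4 `COc1cc(Cl)cc(-c2nn(-c3cccc(NC(=O)Nc4ccc(Cl)c(Cl)c4)c3)cc2-c2ccncc2)c1` has not yet been measured and differs from compound 3 by chloro in place of trifluoromethyl on an aromatic carbon. For the measured compounds named here, the only measured step touching this group is a number 89.2 percentage points lower from compound 1 to compound 3 (beyond the scatter), yet that step also alters the link to the carbonyl carbon, so it bears on the new change only in part. A step down beyond the scatter is expected, a number 20 percentage points lower from compound 3 to compound 4 (beyond the scatter), because compound 2 gives -70.3% while carrying the same (3,4-dichlorophenyl)amino group on the carbonyl carbon. Compound 4 is therefore estimated at -50%, within -85% to -10%.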

Compound 4, a percentage reported as activity, at one concentration (the size of the read-out at that concentration, not a potency): 4.46%
For compound 4 the middle estimate is 54.5 percentage points below the measured one, and the stated range ends below it.
By their numbers in this assay, from the lowest: compound 2; then compound 3; then compound 4; then compound 1.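

In this assay chloro in place of trifluoromethyl on an aromatic carbon gives a number 34.5 percentage points higher from compound 3 to compound 4 (beyond the scatter) and so shows that this position alone moves the read-out, with chloro giving the weaker effect. (3,4-Dichlorophenyl)amino in place of 3,4-dichlorophenyl on the carbonyl carbon gives a number 54.7 percentage points lower from compound 1 to compound 4 (beyond the scatter) and so separates the link change from the ring change, which the earlier step mixed. Methyl in place of hydrogen on an oxygen on an aromatic ring gives a number 74.8 percentage points higher from compound 2 to compound 4 (beyond the scatter) and so shows that this site matters too.

Nothing measured here explains these steps. Going by these compounds, whether bromo or a nitrile at this position would give a stronger or weaker effect stays open.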